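Pyridazine to pyridine on a piperidine nitrogen: hepatocyte half-life

This account rests on a few compounds, and the source may have more. Where it says the series, first, only, none or still open, it means among the compounds named here.

Measured compounds:
- compound 1, `Cc1nnc(N2CCC(C(=O)N3N=CC[C@H]3c3cc(F)cc(F)c3)CC2)o1`, 3.3 h in an ADME assay on cells (Hepatocyte, Rattus norvegicus) for metabolic stability; on this read-out lower numbers stand for a shorter-lived compound and higher numbers for a longer-lived compound
- compound 2, `O=C(C1CCN(c2cccnn2)CC1)N1N=CC[C@H]1c1ccccc1`, < 0.517 h in this assay
- compound 3, `N#Cc1cc(N2CCC(C(=O)N3N=CC[C@H]3c3cc(F)cc(F)c3)CC2)ncn1`, 1.15 h in this assay

Compound 2 does not give a number in this assay; its result is a limit, (the limit of < 0.517 h in this assay, at which 1 of the 3 values shown sits), so it stands at the short-lived end of what this assay reports. Compound 4, `O=C(C1CCN(c2ccccn2)CC1)N1N=CC[C@H]1c1ccccc1`, differs from compound 2 in one place: pyridin-2-yl in place of pyridazin-3-yl on an amine nitrogen in a ring.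

Within the data shown here, only one measured step exists, a 2.9-fold lower number from compound 1 to compound 3 (0.46 log units; beyond the scatter), and it concerns a different pair of rings on a different core, so it does not bear on the exchange of pyridazin-3-yl for pyridin-2-yl. Among the measured compounds shown here, no measured pair shows what that exchange does. The expectation for compound 4 therefore rests on compound 2 alone, whose result in this assay is a limit and gives no fixed starting number.

Compound 4 is expected to remain short-lived, with the step that the limit leaves unreadable from compound 2 to compound 4 not expected to lie beyond the scatter. The estimate for compound 4 in this assay is 0.5 h, between 0.2 h and 1.5 h, with a fair chance that only a limit is reported again.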

Compound 4, half-life: 0.0633 h
Compound 4: middle estimate off by 7.9-fold (0.90 log units), on the high side; measured number below the stated range.
By their numbers in this assay, from the lowest: compound 4; then compound 3; then compound 1.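

The exchange from compound 2 to compound 4 gives no readable step in this assay, because compound 2 carries only a limit: the limit of < 0.517 h in this assay, at which 1 of the 4 values shown sits.

The compounds shown leave open how large the change from pyridazin-3-yl to pyridin-2-yl is, and in which direction it runs.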